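Step from compound 3 to compound 4: loss of the phenyl

The compounds below may be only part of what the source reports. "The series", "measured", "known", "first", "only" and "open" are said of these compounds alone.

Measured compounds:
compound 1 `CCOc1cc(NC(=O)CCCCCNC(=O)CCCc2ccccc2)cc2c1OCC([N+](=O)[O-])=C2`: 3320 nM
compound 2 `CCOc1cc(NC(=O)CCCCCC(=O)Nc2cc(-c3ccc(C)s3)ccc2N)cc2c1OCC([N+](=O)[O-])=C2`: 2920 nM
compound 3 `CCOc1cc(NC(=O)CCCCCC(=O)Nc2cc(-c3ccccc3)ccc2N)cc2c1OCC([N+](=O)[O-])=C2`: 3210 nM

In a functional assay on K562 cells (Homo sapiens) for antiproliferative activity, read by MTT assay, with a stated time of 48 h (on this read-out higher numbers stand for weaker inhibition of growth and lower numbers for stronger inhibition of growth), compound 3 stands second highest of the three numbers; its nearest neighbour is compound 1 and its furthest compound 2, and both gaps lie within the scatter. Among the compounds with values here, the one measured step, a 1.1-fold higher number from compound 2 to compound 3 (0.04 log units; within the scatter), exchanges one aromatic ring for another and leaves the number essentially unchanged.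

Compound 4 `CCOc1cc(NC(=O)CCCCCC(=O)Nc2ccccc2N)cc2c1OCC([N+](=O)[O-])=C2` differs from compound 3 by hydrogen in place of phenyl on an aromatic carbon. Within the data shown here, no measured step removes this ring outright, so the closest guide is indirect: compound 1, a structure that differs from compound 3 in more than one place, gives a number within the scatter of both compound 2 and compound 3, and the exchange of rings from compound 2 to compound 3 did not move the read-out either. Across these three structures the aromatic end of the chain has not shifted this assay beyond the scatter.

Compound 4 is therefore expected to give 3400 nM, with a range of 1500 nM to 8000 nM. Among the measured compounds shown here, this estimate means a step of a 1.1-fold higher number from compound 3 to compound 4 (0.02 log units; within the scatter), within the scatter; the range is kept wide because no measured step removes a whole ring.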

Compound 4, concentration for 50% growth inhibition: 3960 nM
Beside the measured number, compound 4's estimate is 1.2-fold (0.07 log units) below it; low and high end bracket the measured number.
By their numbers in this assay, from the lowest: compounds 2, 3, 1 and 4 (each within the scatter of the next).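

In this assay, within the data shown here, hydrogen in place of phenyl gives a 1.2-fold higher number from compound 3 to compound 4 (0.09 log units; within the scatter) and so extends the earlier picture: the earlier compounds showed only one aromatic ring exchanged for another on this aromatic carbon, whereas here the ring is absent altogether. Hydrogen in place of 5-methylthiophen-2-yl gives a 1.4-fold higher number from compound 2 to compound 4 (0.13 log units; within the scatter) and leads to the same reading, so the number on this read-out does not depend on either ring being present. At the other change, (2-aminophenyl)carbamoyl in place of ((3-phenylpropyl)carbonyl)amino gives a 1.2-fold higher number from compound 1 to compound 4 (0.08 log units; within the scatter) and likewise leaves the number within the scatter.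

Open, from the compounds shown here alone, is whether an amine, a carboxylic acid or a longer chain on this aromatic carbon would move the number beyond the scatter. The data offer no explanation for the flat read-out.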